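A few compounds are considered here, and "the series" means these few. Any claim that something is new, unique, unknown or untested is made for them only; others in the source may bear on it.

Compound 1 `COc1ccc(Br)cc1CCc1ccccc1-c1ncc(C)n1C` is the strongest of the three measured compounds in a functional assay on HEK293 cells (Homo sapiens), read by cAMP accumulation (a higher number here means a weaker inhibitor, a lower number a stronger inhibitor), giving 51 nM. Compound 2 `CCc1cnc(-c2ccccc2CCc2cc(Br)ccc2OC)n1C` gives 170 nM in this assay, and compound 3 `CCc1cn(C)c(-c2ccccc2CCc2cc(Br)ccc2OC)n1` gives 820 nM, the highest of the three numbers: it is separated from compound 2 by a 4.8-fold higher number from compound 2 to compound 3 (0.68 log units; beyond the scatter) and from compound 1 by a 16-fold higher number from compound 1 to compound 3 (1.21 log units; beyond the scatter), so compound 3 is the weakest inhibitor seen so far.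

Compound 4 `COc1ccc(Br)cc1CCc1ccccc1-c1nc(C(C)C)cn1C` differs from compound 3 by methyl in place of hydrogen on a saturated chain carbon bound to an aromatic carbon and a saturated chain carbon. Among the measured compounds shown here, the one measured step of the same kind, adding a methyl to a saturated chain carbon bound to an aromatic carbon, is a 3.3-fold higher number from compound 1 to compound 2 (0.52 log units; beyond the scatter), a modest weakening. For the measured compounds named here, no measured step covers growth from ethyl to isopropyl, so the size for compound 4 rests on that single step. The expected change from compound 3 to compound 4 in this assay is therefore a 2.4-fold higher number from compound 3 to compound 4 (0.39 log units; beyond the scatter), a modest weakening. Compound 4 is estimated to give 2000 nM in this assay, with a likely range from 800 nM to 5000 nM.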

Compound 4, half-maximal inhibitory concentration: 1200 nM
The estimate for compound 4 lay 1.7-fold (0.22 log units) above the measured number; the range from low to high includes it.
By their numbers in this assay, from the lowest: compound 1; then compound 2; then compounds 3 and 4 (each within the scatter of the next).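

Growing ethyl to isopropyl, with methyl in place of hydrogen on a saturated chain carbon bound to an aromatic carbon and a saturated chain carbon, gives a 1.5-fold higher number from compound 3 to compound 4 (0.17 log units; within the scatter). In this assay, this position therefore takes the extra methyl with no change that can be told from the scatter of repeated measurements. Until now, adding a methyl to a chain carbon had been read only once, on another core, and the two readings do not differ by more than the scatter, so they do not show that the change behaves differently on the two cores: the same change on two cores in this assay, a 3.3-fold higher number (0.52 log units; beyond the scatter) from compound 1 to compound 2 and a 1.5-fold higher number (0.17 log units; within the scatter) from compound 3 to compound 4, 2.3-fold (0.36 log units) apart, within the scatter of two such steps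

Open, as far as these compounds go, is how a longer chain such as butyl, a cyclopropyl ring or an amine would read in this place in this assay. Also open, from the compounds shown here alone, is how isopropyl would read on the core of compound 1, which would give a third reading of this change.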